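This account rests on a few compounds, and the source may have more. Where it says the series, first, only, none or still open, it means among the compounds named here.

Compound 3 `C[C@@H](O[C@@H]1CN(C(=O)[C@@H]2COC(=O)N2)C[C@H]1c1ccc(F)cc1)c1cc(C(F)(F)F)cc(C(F)(F)F)c1` is the one to start from. In an assay on CHO cells for displacement of a labelled ligand from Substance-P receptor (Homo sapiens) (a higher number here means a weaker inhibitor, a lower number a stronger inhibitor), compound 3 gives 0.34 nM, the highest of the three numbers recorded. The two others share its core and differ only in the group on the carbonyl carbon: compound 1 `CCC(=O)N1C[C@@H](O[C@H](C)c2cc(C(F)(F)F)cc(C(F)(F)F)c2)[C@H](c2ccc(F)cc2)C1` gives 0.09 nM in this assay, and compound 2 `CC(=O)N1CCC(C(=O)N2C[C@@H](O[C@H](C)c3cc(C(F)(F)F)cc(C(F)(F)F)c3)[C@H](c3ccc(F)cc3)C2)CC1` gives 0.07 nM. Between those two the step is small, a 1.3-fold lower number from compound 1 to compound 2 (0.11 log units; within the scatter), whereas the steps onto compound 3 are both beyond the scatter: a 3.8-fold higher number from compound 1 to compound 3 (0.58 log units; beyond the scatter) and a 4.9-fold higher number from compound 2 to compound 3 (0.69 log units; beyond the scatter).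

Compound 4 `C[C@@H](O[C@@H]1CN(C(=O)NCc2cn[nH]n2)C[C@H]1c1ccc(F)cc1)c1cc(C(F)(F)F)cc(C(F)(F)F)c1` takes the same position in hand once more: ((2H-1,2,3-triazol-4-yl)methyl)amino in place of 2-oxo-1,3-oxazolidin-4-yl on a carbonyl carbon. All three measured steps touch this very place, and they show that the group on that carbonyl carbon can move the number by a modest amount in either direction, with the two-oxo-oxazolidinyl arrangement giving the weaker binding. The entering group resembles none of the three measured ones, so a step of modest size toward lower numbers, or no step beyond the scatter, is what the data make plausible. For compound 4 the expected value in this assay is therefore 0.2 nM, within a range from 0.06 nM to 0.7 nM, which would correspond to an expected step of a 1.7-fold lower number from compound 3 to compound 4 (0.23 log units; within the scatter).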

Compound 4, half-maximal inhibitory concentration: 0.58 nM
The estimate for compound 4 lay 2.9-fold (0.46 log units) below the measured number; low and high end bracket the measured number.
By their numbers in this assay, from the lowest: compounds 2 and 1 (each within the scatter of the next); then compounds 3 and 4 (each within the scatter of the next).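

In this assay, a very different group can take this place with no readable change: a 1.7-fold higher number from compound 3 to compound 4 (0.23 log units; within the scatter). The leaving group is a non-aromatic ring holding oxygen, and the entering one is an aromatic ring holding only nitrogen and carried on an amino link, yet the two cannot be told apart here. Compound 4 nevertheless stays clearly apart from the ethyl and 1-acetylpiperidin-4-yl groups, with a 6.4-fold higher number from compound 1 to compound 4 (0.81 log units; beyond the scatter) and an 8.3-fold higher number from compound 2 to compound 4 (0.92 log units; beyond the scatter), so the four compounds fall into two pairs, although nothing shown explains this split.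

As far as these compounds go, the entering group also brings the amino link and the methyl chain, so the contribution of the triazole ring itself stays open. A plain methylamino group on the same carbonyl carbon, or a triazole ring carried there without the amino link, would separate these parts.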